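Swapping the Dimethylamino Group for a Silicon Group

The source may report more compounds than this note shows. Statements on the series, on what has been measured and on what is new or still open speak of the compounds shown alone.

- Compound 1 `CC(=O)OC/C1=C/C[C@](C)(CCC=C(C)C)/C=C/[C@@H](OC(=O)C=C(C)C)[C@](C)(O)/C=C/C1=O`: 2950 nM
- Compound 2 `CC(C)=CCC[C@]1(C)/C=C/[C@@H](OC(=O)C=C(C)C)[C@](C)(O)/C=C/C(=O)/C(CN(C)C)=C\C1`: 480 nM

Both numbers come from a functional assay on SW480 cells (Homo sapiens) for antiproliferative activity, read by MTT assay, with a stated time of 48 h; a lower number here means a stronger inhibitor, a higher number a weaker inhibitor. Going by the values given here, of the two compounds measured so far, compound 2 has the lower number, at 480 nM, so it is the stronger inhibitor of this pair.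

The next compound is compound 3 `CC[Si](CC)(CC)C/C1=C/C[C@](C)(CCC=C(C)C)/C=C/[C@@H](OC(=O)C=C(C)C)[C@](C)(O)/C=C/C1=O`, which keeps the shared core but changes one group. The change is a group of 7 heavy atoms (6 carbon, 1 silicon; no ring) in place of a group of 3 heavy atoms (2 carbon, 1 nitrogen; no ring), on a saturated chain carbon bound to a double-bonded ring carbon. The new group contains silicon and no nitrogen, so the dimethylamino group is gone.

Among the compounds with values here, only one measured step bears on this change: a 6.1-fold lower number from compound 1 to compound 2 (0.79 log units; beyond the scatter). That step put dimethylamino in place of acetoxy at the same place, and it is a modest step beyond the scatter. Within the data shown here, no measured compound carries the silicon group, so its own contribution is unknown. Losing the dimethylamino group may give back part or all of that gain, so a higher number is expected, with wide uncertainty.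

The expected change is a 3.1-fold higher number from compound 2 to compound 3 (0.49 log units; beyond the scatter). For compound 3 the estimate is 1500 nM, with an expected range of 400 nM to 6000 nM.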

Compound 3, half-maximal inhibitory concentration: 2690 nM
Compound 3: the middle estimate sits 1.8-fold (0.25 log units) below what was measured; low and high end bracket the measured number.
By their numbers in this assay, from the lowest: compound 2; then compounds 3 and 1 (each within the scatter of the next).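

In this assay, replacing dimethylamino with the silicon group gives a 5.6-fold higher number from compound 2 to compound 3 (0.75 log units; beyond the scatter), so the gain seen at this saturated chain carbon bound to a double-bonded ring carbon does not carry over to this new group. Setting the silicon group against acetoxy at the same place gives a 1.1-fold lower number from compound 1 to compound 3 (0.04 log units; within the scatter), so these two very different groups cannot be told apart here, and among the three groups tested only dimethylamino stands out. Nothing measured explains why the silicon group and acetoxy read alike or why dimethylamino differs from both.

Going by these compounds alone, with only one nitrogen-bearing group in this set, it remains open whether the lower number belongs to amines at this place in general or to dimethylamino alone; diethylamino, a morpholine ring or a primary amine could separate those two readings. A triethylmethyl group, which has carbon where the silicon group has silicon, would show whether the silicon atom itself matters at all.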